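Carboxy in Place of Hydroxy on a Shared Core

A few compounds are considered here, and "the series" means these few. Any claim that something is new, unique, unknown or untested is made for them only; others in the source may bear on it.

Compound 1 `ONc1cccc(CNc2cc(Br)cc3[nH]ncc23)c1`: "not active" (no number reported)
Compound 2 `N#Cc1ccc(CNc2cc(Br)cc3[nH]ncc23)cc1`: 73%
Compound 3 `Nc1nc(CNc2cc(Br)cc3[nH]ncc23)cs1`: 73%

Of the compounds shown here, three built on the same core have been tested in an assay for inhibition of Tryptophan 2,3-dioxygenase (Homo sapiens), with a stated time of 1 h, tested at 10 uM; on this read-out lower numbers stand for less inhibition and higher numbers for more inhibition at the one concentration tested (going by the name of the read-out). Compound 1 was reported as "not active" (no number reported), with no number attached, so it stands apart from the other two without a value of its own to place it. In this assay compound 2 gives 73% and compound 3 gives 73%; these two values lie within the usual scatter of each other, so they show the same level of inhibition.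

Compound 4 `O=C(O)Nc1cccc(CNc2cc(Br)cc3[nH]ncc23)c1` has not yet been measured. It differs from compound 1 in a single place: carboxy in place of hydroxy on a nitrogen on an aromatic ring. For the measured compounds named here, no step between measured compounds mirrors this change, so nothing measured says how large a shift to expect. Since compound 1 gave no number, a step from it cannot be sized either way. The expectation is a small step in this assay, in either direction, most likely none beyond the scatter. For compound 4 the estimated inhibition in this assay is 20%, with a range from 0% to 55%.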

Compound 4, a percentage reported as inhibition, at one concentration (the size of the read-out at that concentration, not a potency): "not active" (no number reported)
Compound 4 has no reported number here, and the estimate cannot be compared.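

In this assay compound 1 gives "not active" (no number reported) and compound 4 gives "not active" (no number reported) with no number on either side, so no step can be read between them. Nothing measured here bears on this result. The compounds shown leave open whether changing hydroxyamino to carboxyamino on the shared core alters inhibition at all.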